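Adding a Second Chloro to the Trifluoromethylpyridine of Compound 3

This account rests on a few compounds, and the source may have more. Where it says the series, first, only, none or still open, it means among the compounds named here.

Compound 1 `S=C(Nc1cccnc1)NC1CCN(c2cc(Cl)ccn2)CC1` — in an assay on membranes from brain for binding affinity to Lysophosphatidylserine lipase ABHD12 (Mus musculus), read by fluorescence, with a stated time of 20 min (on this read-out lower numbers stand for stronger inhibition and higher numbers for weaker inhibition), compound 1 gives 2100 nM.
Compound 2 `FC(F)(F)c1cc(Cl)nc(N2CCC(NC(=S)Nc3cccnc3)CC2)c1` — in this assay compound 2 gives 540 nM.
Compound 3 `FC(F)(F)c1ccnc(N2CCC(NC(=S)Nc3cccnc3)CC2)c1` — in this assay compound 3 gives 640 nM.

Compound 3 stands second highest of the three numbers. Among the compounds with values here, its nearest neighbour is compound 2, whose number lies within the scatter of it; the only step beyond the scatter is a 3.3-fold lower number from compound 1 to compound 3 (0.52 log units; beyond the scatter), which brought the number down when the trifluoromethyl group replaced the chloro on the shared core.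

Compound 4 `FC(F)(F)c1cc(N2CCC(NC(=S)Nc3cccnc3)CC2)ncc1Cl` differs from compound 3 in one place: chloro in place of hydrogen on an aromatic carbon. The measured step that bears most directly on this is a 1.2-fold higher number from compound 2 to compound 3 (0.07 log units; within the scatter), where removing a chloro from the same ring left the number within the scatter. Within the data shown here, a chloro entering the ring is therefore expected to move the number little, though the position now differs from that in compound 2, and no measured pair speaks to that exact place. The expected step is a 1.1-fold lower number from compound 3 to compound 4 (0.06 log units; within the scatter), no change beyond the scatter in this assay. Compound 4 is accordingly estimated at 560 nM, with a range from 250 nM to 1300 nM.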

Compound 4, half-maximal inhibitory concentration: 1400 nM
Estimate against measurement, compound 4: 2.5-fold (0.40 log units) below, outside the stated range (above it).
By their numbers in this assay, from the lowest: compounds 2 and 3 (each within the scatter of the next); then compounds 4 and 1 (each within the scatter of the next).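

In this assay, a chloro entering on the aromatic carbon ortho to a trifluoromethyl group, two atoms from the ring nitrogen and para to a large group, gives a 2.2-fold higher number from compound 3 to compound 4 (0.34 log units; beyond the scatter), a modest step that nonetheless lies beyond the scatter. The earlier chloro change on this ring, a 1.2-fold higher number from compound 2 to compound 3 (0.07 log units; within the scatter), stayed within the scatter, so across these two places on the ring of compound 3, the outcome of the change depends on where the chloro sits. No measurement shown here bears on why this place differs from the other, and the difference stays unexplained.

At this place the compounds shown carry only hydrogen or chloro, which leaves open whether a fluoro, a methyl, a methoxy or an amine there would raise the number as chloro does or leave it unchanged. Within the data shown here, they also leave open whether the step depends on the neighbouring trifluoromethyl group, since no pair shows this chloro entering a ring that carries another group in its stead.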